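Adding a 4-chlorophenyl Group to a Weak Adenosine Agonist

This account rests on a few compounds, and the source may have more. Where it says the series, first, only, none or still open, it means among the compounds named here.

Among the compounds with values here, compound 1 `CCOC(=O)c1c(-c2cccc(C(F)(F)F)c2)csc1N` was tested in a functional assay on CHO-K1 cells for agonist activity at adenosine receptor A1 (Homo sapiens), read by GTPgammaS binding (a higher number here means that more compound is needed for the effect, a lower number that less compound is needed), and gave 9.4 uM, the only numeric value so far in this set. The related compound 2 `CC(=O)c1ccc(-c2sc(N)c(C(=O)c3ccccc3)c2-c2cccc(C(F)(F)F)c2)cc1` gave in this assay only a limit, > 10 uM, at the edge of what the assay reports; that edge is the limit of > 10 uM in this assay, at which 1 of the 2 values shown sits. Within the data shown here, compound 1 thus stands as the one measured number, with compound 2 sitting at the limit.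

Compound 3 `CCOC(=O)c1c(N)sc(-c2ccc(Cl)cc2)c1-c1cccc(C(F)(F)F)c1` differs from compound 1 in one place: 4-chlorophenyl in place of hydrogen on an aromatic carbon. The new group sits next to the ring sulfur of the shared core. Among the measured compounds shown here, no measured pair shows what such an addition does here, so any expectation rests on compound 1 alone. The step from compound 1 to compound 3 in this assay is expected to be small and in the direction of less compound needed, a 1.9-fold lower number from compound 1 to compound 3 (0.27 log units; within the scatter). For compound 3 the estimated value in this assay is 5 uM, with a likely range from 1.5 uM to 20 uM.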

Compound 3, concentration for half-maximal effect: 6.6 uM
Beside the measured number, compound 3's estimate is 1.3-fold (0.12 log units) below it, and the stated range covers the measured number.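

At the carbon next to the ring sulfur, 4-chlorophenyl in place of hydrogen gives in this assay a 1.4-fold lower number from compound 1 to compound 3 (0.15 log units; within the scatter), so this change cannot be told apart from repeat-measurement noise. Within the data shown here, this is the first direct reading for this position: it can carry a whole added aromatic ring with no change beyond the scatter, and compound 3 still gives a real number rather than a limit of the assay. Nothing shown here gives a measured property that would bear on this step.

Going by these compounds, whether a small group at this position, such as methyl or an amine, would shift the number beyond the scatter remains open. Also open, on these data alone, is whether a carboxylic acid on the added phenyl ring, in place of the chlorine, would do so.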